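The source may hold more compounds than are shown below. What is called first, only, known or untested is meant among the compounds shown, and "the series" means these compounds.

Measured compounds in a functional assay on MCF7 cells (Homo sapiens) for antiproliferative activity, read by MTT assay, with a stated time of 72 h; a higher number here means a weaker inhibitor, a lower number a stronger inhibitor:

Compound 1 `CC1=CC[C@H]2[C@H](CC[C@]2(C)O)C(C)(C)[C@@H]1CC[C@H]1[C@]2(C)CC[C@H](OC(=O)c3ccncc3)C(C)(C)O[C@H]2CC[C@@]1(C)O` gives 25300 nM in this assay.
Compound 2 `CC1=CC[C@H]2[C@@H]1CC=C(C)[C@@H](CC[C@H]1[C@]3(C)CC[C@H](OC(=O)c4ccccc4)C(C)(C)O[C@H]3CC[C@@]1(C)O)C2(C)C` gives 23100 nM in this assay.
Compound 3 `CC1=CC[C@H]2[C@H](CC[C@]2(C)O)C(C)(C)[C@@H]1CC[C@H]1[C@]2(C)CC/C(=N/OC(=O)c3ccccc3)C(C)(C)O[C@H]2CC[C@@]1(C)O` gives 25600 nM in this assay.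

The three numbers lie close together. Compound 1 sits between compound 3 and compound 2, and both gaps are within the usual scatter of repeated measurements, so no order among the three can be read from these values; all three behave alike in this assay as far as this data set shows. Among the measured compounds shown here, no step between two measured compounds that differ in a single place is available, so the effect of exchanging one group for another at the ester has not been measured directly.

Compound 4 `CC1=CC[C@H]2[C@H](CC[C@]2(C)O)C(C)(C)[C@@H]1CC[C@H]1[C@]2(C)CC[C@H](OC(=O)c3ccco3)C(C)(C)O[C@H]2CC[C@@]1(C)O` is not yet measured. It differs from compound 1 in one place: furan-2-yl in place of pyridin-4-yl on a carbonyl carbon. The shared core of compound 1 is kept unchanged.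

Given that compound 1, compound 2 and compound 3 all give values that agree within the scatter in this assay despite different groups on the ester, the expectation for compound 4 is a step of a 1.0-fold lower number from compound 1 to compound 4 (0.01 log units; within the scatter), that is, none beyond the scatter. The estimate for compound 4 is 25000 nM, with an expected range from 12000 nM to 52000 nM.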

Compound 4, half-maximal inhibitory concentration: 25700 nM
Beside the measured number, compound 4's estimate is 1.0-fold (0.01 log units) below it; measured number inside the range.
By their numbers in this assay, from the lowest: compounds 2, 1, 3 and 4 (each within the scatter of the next).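

In this assay, among the compounds shown here, furan-2-yl in place of pyridin-4-yl on a carbonyl carbon gives a 1.0-fold higher number from compound 1 to compound 4 (0.01 log units; within the scatter) and is the first direct single-place reading. The earlier compounds shown here could only suggest that this position tolerates different groups, since none of them formed a pair differing in one place. This pair now shows that, on the unchanged shared core, a five-membered aromatic ring with an oxygen and a six-membered aromatic ring with a nitrogen cannot be told apart by this read-out.

On these data alone, the reading covers only these two aromatic rings, so it remains open whether an amine, a carboxylic acid or a longer alkyl chain in place of the pyridin-4-yl group would also stay within the scatter of compound 1. Also open, as far as these compounds go, is whether a free hydroxyl in place of the whole ((pyridin-4-yl)carbonyl)oxy group would give a value distinct from that of compound 1, and so whether the ester is needed at all. No separate measurement bears on this result.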